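This account rests on a few compounds, and the source may have more. Where it says the series, first, only, none or still open, it means among the compounds named here.

Of the compounds shown here, two have been measured in an assay on isolated protein for binding affinity to Equilibrative nucleoside transporter 1 (Homo sapiens); a lower number here means a stronger inhibitor, a higher number a weaker inhibitor. Compound 1 `Cc1cccc(CSc2ncnc3c2ncn3[C@@H]2O[C@H](CO)[C@@H](O)[C@H]2O)c1` gives 12000 nM. Compound 2 `Nc1nc(SCc2cccc(Br)c2)c2ncn([C@@H]3O[C@H](CO)[C@@H](O)[C@H]3O)c2n1` gives 2880 nM, the lowest of the two numbers, and its gap to compound 1 lies beyond the usual scatter, so compound 2 is the stronger inhibitor of the pair. Compound 3 `CC(=O)c1ccccc1Sc1nc(N)nc2c1ncn2[C@@H]1O[C@H](CO)[C@@H](O)[C@H]1O` has not yet been measured. It differs from compound 2 in one place: 2-acetylphenyl in place of 3-bromobenzyl on a sulfur. The group that leaves carries a bromine and no hydrogen-bond acceptor; the group that enters carries one hydrogen-bond acceptor and one double bond outside the aromatic ring. Among the compounds with values here, no measured pair shows what such a change does here, so the expectation rests on compound 2 alone. The expected step of a 2.4-fold higher number from compound 2 to compound 3 (0.39 log units; beyond the scatter) is a move to a higher number, a weaker inhibitor, beyond the scatter. Compound 3 is estimated at 7000 nM, with a range from 1500 nM to 30000 nM.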

Compound 3, half-maximal inhibitory concentration: 447000 nM
Compound 3: middle estimate off by 64-fold (1.81 log units), on the low side; measured number above the stated range.
By their numbers in this assay, from the lowest: compound 2; then compound 1; then compound 3.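

In this assay, within the data shown here, the single swap of 3-bromobenzyl for 2-acetylphenyl on the sulfur moves the number a 160-fold higher number from compound 2 to compound 3 (2.19 log units; beyond the scatter) and so gives a far weaker inhibitor. This shows that the group on this sulfur is not a tolerant spot, since one change here, with the rest of compound 2 held fixed, can cost a great deal of strength. No measurement shown here explains the size of this step.

The swap changes several things at once: it removes the bromine, adds the acetyl group and replaces a benzyl with a phenyl, so the compounds shown do not tell which of these matters. A plain benzyl, a plain phenyl or a 3-bromophenyl on the same sulfur would begin to separate them.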